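Naphthyl Replaces Nitrophenyl on a Sulfonamide Core

A few compounds are considered here, and "the series" means these few. Any claim that something is new, unique, unknown or untested is made for them only; others in the source may bear on it.

Measured compounds:
compound 1 `O=C(O)CCC/C=C\C[C@H]1[C@@H]2CCC(C2)[C@@H]1NS(=O)(=O)c1ccc([N+](=O)[O-])cc1` — 1400 nM
compound 2 `Cc1ccccc1S(=O)(=O)N[C@H]1C2CC[C@H](C2)[C@@H]1C/C=C\CCCC(=O)O` — 6200 nM
compound 3 `CN(C)c1ccc(S(=O)(=O)N[C@H]2C3CC[C@H](C3)[C@@H]2C/C=C\CCCC(=O)O)cc1` — 7100 nM

In a functional assay (plasma) for inhibition, with Oryctolagus cuniculus as the target (on this read-out higher numbers stand for weaker inhibition and lower numbers for stronger inhibition), compound 1 gives 1400 nM, the lowest of the three numbers, so it is the strongest inhibitor among them. The two measured steps both start from it and both weaken inhibition: a 4.4-fold higher number from compound 1 to compound 2 (0.65 log units; beyond the scatter) and a 5.1-fold higher number from compound 1 to compound 3 (0.71 log units; beyond the scatter), each beyond the scatter. Compound 2 and compound 3 sit within the scatter of each other, as a 1.1-fold higher number from compound 2 to compound 3 (0.06 log units; within the scatter) shows.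

Compound 4 `O=C(O)CCC/C=C\C[C@H]1[C@@H]2CCC(C2)[C@@H]1NS(=O)(=O)c1cccc2ccccc12` differs from compound 1 in one place: naphthalen-1-yl in place of 4-nitrophenyl on a sulfonyl sulfur. Neither measured step tests this exact change, but both show that leaving the 4-nitrophenyl of compound 1 costs activity in this assay, and naphthalen-1-yl also removes the nitro group. A weakening of similar size is therefore expected, written as a 2.9-fold higher number from compound 1 to compound 4 (0.46 log units; beyond the scatter), though the wide spread of possible outcomes is acknowledged. Compound 4 is expected to give about 4000 nM in this assay, between 900 nM and 15000 nM.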

Compound 4, half-maximal inhibitory concentration: 1100 nM
Beside the measured number, compound 4's estimate is 3.6-fold (0.56 log units) above it, within the range that was stated.
By their numbers in this assay, from the lowest: compounds 4 and 1 (each within the scatter of the next); then compounds 2 and 3 (each within the scatter of the next).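

In this assay, the nitro group of compound 1 proves dispensable on this sulfonyl sulfur: naphthalen-1-yl, which holds only carbon, gives a 1.3-fold lower number from compound 1 to compound 4 (0.10 log units; within the scatter) and leaves the two compounds indistinguishable. The earlier steps shown here showed only that leaving 4-nitrophenyl could cost activity. The new steps, a 5.6-fold lower number from compound 2 to compound 4 (0.75 log units; beyond the scatter) and a 6.5-fold lower number from compound 3 to compound 4 (0.81 log units; beyond the scatter), show that losing the nitro group does not by itself weaken inhibition, since both 2-methylphenyl and 4-(dimethylamino)phenyl fall short of naphthalen-1-yl, which also lacks it.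

The compounds shown leave open whether an unsubstituted phenyl, or a phenyl bearing a chlorine or a nitrile, would match these two groups. They also leave open how naphthalen-2-yl would compare. No evidence is available here to explain these differences.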